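The source may report more compounds than this note shows. Statements on the series, on what has been measured and on what is new or still open speak of the compounds shown alone.

Working notes on the series. The shared core is that of compound 1 `Cc1ccccc1Nc1nc(NC2CC2)ncc1Cl`. In a functional assay on MDA-MB-231 cells (Homo sapiens) for inhibition, read by CCK-8 assay, with a stated time of 48 h (on this read-out lower numbers stand for stronger inhibition of growth and higher numbers for weaker inhibition of growth), compound 1 returns only a limit, > 100000 nM. Compound 2 `Cc1ccccc1Nc1nc(Nc2ccc(N3CCCCC3)cn2)ncc1Cl` likewise returns only a limit in this assay, > 100000 nM. Among the measured compounds shown here, compound 3 `COc1ccc(CNc2nc(Nc3ccc(N4CCN(C)CC4)cn3)ncc2Cl)cc1` is the single member of the set with a measured number: in this assay compound 3 gives 14900 nM. For the measured compounds named here, the remaining values are the limit of > 100000 nM in this assay, at which 2 of the 3 values shown sit, so compound 3 stands alone as the only point with a number, and no order among the three can be drawn from it.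

Compound 4 `COc1ccc(Nc2nc(Nc3ccc(N4CCN(C)CC4)cn3)ncc2Cl)cc1` is not yet measured. It differs from compound 3 in one place: 4-methoxyphenyl in place of 4-methoxybenzyl on a nitrogen on an aromatic ring. Going by the values given here, no step between two measured compounds is available in this assay, so the size of such a change is not read from the data. The expectation for compound 4 is a gain of a 5.0-fold lower number from compound 3 to compound 4 (0.70 log units; beyond the scatter), somewhat beyond the usual scatter. Compound 4 is estimated at 3000 nM, with a range from 500 nM to 20000 nM.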

Compound 4, concentration for 50% growth inhibition: 8020 nM
The estimate for compound 4 lay 2.7-fold (0.43 log units) below the measured number, and the stated range covers the measured number.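

In this assay the series now has its first readable step, a 1.9-fold lower number from compound 3 to compound 4 (0.27 log units; within the scatter), for 4-methoxyphenyl in place of 4-methoxybenzyl on a nitrogen on an aromatic ring. On this evidence the two groups cannot be told apart at this position, so the benzyl and phenyl forms of the 4-methoxy-substituted amine count as equivalent in this read-out. The earlier compounds shown here could not show this, as none of them formed a step with another measured compound.

The compounds shown leave open whether a 2-phenylethyl chain on this nitrogen, or a carboxylic acid in place of the methoxy group, would move the number beyond the scatter. Any steps to the remaining compounds cannot be read, as their values are limits and not numbers: the limit of > 100000 nM in this assay, at which 2 of the 4 values shown sit.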